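Moving from Trifluoromethyl to Ethoxycarbonyl on the Aryl Urea

The compounds below may be only part of what the source reports. "The series", "measured", "known", "first", "only" and "open" are said of these compounds alone.

Compound 1 `C[C@@H](NC(=O)Nc1cccc(C(F)(F)F)c1)c1ccccc1` and compound 2 `C[C@@H](NC(=O)Nc1ccc(C(F)(F)F)cc1)c1ccccc1` are built from the same atoms joined differently; the difference between the two cores is not broken down here. In an ADME assay on the whole organism with Oryza sativa as the target, tested at 10 uM (on this read-out higher numbers stand for a weaker effect at the one concentration tested and lower numbers for a stronger effect), compound 1 gives 70% and compound 2 gives 82%. Compound 3 `CCOC(=O)c1cccc(NC(=O)N[C@H](C)c2ccccc2)c1` carries the change ethoxycarbonyl in place of trifluoromethyl on an aromatic carbon and in this assay compound 3 gives 88%, a step of a number 18 percentage points higher from compound 1 to compound 3 (beyond the scatter). The unmeasured compound 4 `CCOC(=O)c1ccc(NC(=O)N[C@H](C)c2ccccc2)cc1` arises from compound 2 by ethoxycarbonyl in place of trifluoromethyl on an aromatic carbon, the same kind of change, though here the new group sits para to a large group rather than meta to a large group. In this assay the expected step is a number 8 percentage points higher from compound 2 to compound 4 (within the scatter), somewhat smaller than the earlier one. That rests on compound 2 already standing at 82%, which leaves less room above it. Compound 4 is therefore estimated at 90%, with a likely range from 80% to 99%.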

Compound 4, a percentage reported as activity, at one concentration (the size of the read-out at that concentration, not a potency): 92%
The estimate for compound 4 lay 2 percentage points below the measured number; measured number inside the range.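

In this assay, the same replacement on the second core gives a step of a number 10 percentage points higher from compound 2 to compound 4 (within the scatter), and the two steps cannot be told apart: the same change on two cores in this assay, a number 18 percentage points higher (beyond the scatter) from compound 1 to compound 3 and a number 10 percentage points higher (within the scatter) from compound 2 to compound 4, 8 percentage points apart, within the scatter of two such steps The change therefore appears to carry over from the core of compound 1 to the core of compound 2 without a detectable difference in this assay. Going by these compounds alone, this does not establish a fixed step size: only two cores are compared, and the step on the second core, taken alone, stays within the scatter.

The compounds shown leave open how other groups, such as a nitrile or a carboxylic acid, would read in place of trifluoromethyl. They also leave open whether the replacement would behave alike on any further core.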